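Shifting the Nitro Group Around the Phenyl Ring

The compounds below may be only part of what the source reports. "The series", "measured", "known", "first", "only" and "open" are said of these compounds alone.

Of the compounds shown here, two from one series have been tested in a functional assay on the whole organism (plasma, strain albino) for inhibition, with Rattus norvegicus as the target, with stated times of 1 h and 4 h, at a dose of 25 mg/kg by the oral route; on this read-out higher numbers stand for a stronger effect at the one dose given and lower numbers for a weaker effect. Compound 1 `COc1ccc(Cl)cc1C(=O)Nc1ccc(C2=NN(C)C(c3ccc([N+](=O)[O-])cc3)C2)cc1` gives 71.4% in this assay. Compound 2 `COc1ccc(Cl)cc1C(=O)Nc1ccc(C2=NNC(c3ccccc3[N+](=O)[O-])C2)cc1` gives 72.3% in this assay. Compound 2 stands within the usual scatter of compound 1, so the two numbers cannot be told apart, and neither compound can be called the more active one.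

Compound 3 `COc1ccc(Cl)cc1C(=O)Nc1ccc(C2=NNC(c3ccc([N+](=O)[O-])cc3)C2)cc1` has not yet been measured. It differs from compound 2 by one change, (4-nitrophenyl in place of 2-nitrophenyl on a saturated ring carbon). Among the compounds with values here, no measured pair in this set isolates the effect of that change by itself, so what follows rests on the two numbers already known.

With both measured compounds sitting close together, the step expected in this assay is a number 2.3 percentage points lower from compound 2 to compound 3 (within the scatter), which is no more than the scatter in either direction. Because compound 1 gives 71.4% while also carrying the 4-nitrophenyl group, compound 3 is estimated at 70%, with a range from 55% to 82%.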

Compound 3, a percentage reported as inhibition, in the whole organism at one dose (the size of the read-out at that dose, not a potency): 76.3%
Compound 3: middle estimate off by 6.3 percentage points, on the low side, within the range that was stated.
By their numbers in this assay, from the lowest: compounds 1, 2 and 3 (each within the scatter of the next).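

Comparing 4-nitrophenyl with 2-nitrophenyl on the saturated ring carbon, with nothing else changed, gives a direct reading in this assay: a number 4 percentage points higher from compound 2 to compound 3 (within the scatter), so moving the nitro group around the phenyl ring leaves these two compounds indistinguishable on this read-out. The methyl on the amine nitrogen in the ring can now be judged by itself too, and hydrogen in its place gives a number 4.9 percentage points higher from compound 1 to compound 3 (within the scatter), again a step that cannot be told apart from repeat-measurement noise. At this single oral dose, neither change separates the compounds, and no supporting measurement is available to explain either small step.

Still open, from the compounds shown here alone, is whether the read-out would hold with an amine or a carboxylic acid in place of the nitro group on the phenyl ring. Also open, going by these compounds, is what an ethyl group or a longer chain would do on the ring nitrogen, where only methyl and hydrogen appear so far, and whether any such change would produce a step clearly larger than the scatter.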